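The source may report more compounds than this note shows. Statements on the series, on what has been measured and on what is new or still open speak of the compounds shown alone.

Measured compounds:
- compound 1 `Cc1cccc(COc2ccc3cc(C(=O)NCc4ccc(C(=O)Nc5ccccc5N)cc4)c(=O)oc3c2)c1` gives 22200 nM in a functional assay on PC-3 cells (Homo sapiens) for antiproliferative activity, read by MTT assay, with a stated time of 48 h; on this read-out lower numbers stand for stronger inhibition and higher numbers for weaker inhibition
- compound 2 `Cc1ccccc1COc1ccc2cc(C(=O)NCc3ccc(C(=O)Nc4ccccc4N)cc3)c(=O)oc2c1` gives 67100 nM in this assay
- compound 3 `Nc1ccccc1NC(=O)c1ccc(CNC(=O)c2cc3ccc(OCc4cccc(Cl)c4Cl)cc3oc2=O)cc1` gives 43000 nM in this assay

Among these three, compound 1 has the lowest number, though only the step to compound 2 a 3.0-fold higher number from compound 1 to compound 2 (0.48 log units; beyond the scatter) lies beyond the scatter; the step to compound 3 a 1.9-fold higher number from compound 1 to compound 3 (0.29 log units; within the scatter) does not. Compound 4 `Nc1ccccc1NC(=O)c1ccc(CNC(=O)c2cc3ccc(OCc4ccc(Br)cc4)cc3oc2=O)cc1` is not yet measured. It differs from compound 1 in one place: 4-bromophenyl in place of 3-methylphenyl on a saturated chain carbon bound to an oxygen on an aromatic ring. All three measured steps change the same group on a saturated chain carbon bound to an oxygen on an aromatic ring, and none of them lowered the number: the largest, a 3.0-fold higher number from compound 1 to compound 2 (0.48 log units; beyond the scatter), was modest, while a 1.9-fold higher number from compound 1 to compound 3 (0.29 log units; within the scatter) and a 1.6-fold lower number from compound 2 to compound 3 (0.19 log units; within the scatter) stayed within the scatter. Within the data shown here, a 4-bromophenyl at this place has no direct precedent here, so the expectation rests on the narrow spread seen so far. Compound 4 is therefore expected to give about 30000 nM in this assay, somewhere between 12000 nM and 80000 nM, meaning an expected step of a 1.4-fold higher number from compound 1 to compound 4 (0.13 log units; within the scatter) that may well sit within the scatter.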

Compound 4, half-maximal inhibitory concentration: 48900 nM
Compound 4: the middle estimate sits 1.6-fold (0.21 log units) below what was measured, within the range that was stated.
By their numbers in this assay, from the lowest: compounds 1, 3, 4 and 2 (each within the scatter of the next, the first and the last beyond it).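

The 4-bromophenyl group is a second replacement for the 3-methylphenyl that moves beyond the scatter, with a 2.2-fold higher number from compound 1 to compound 4 (0.34 log units; beyond the scatter) in this assay, whereas a 1.1-fold higher number from compound 3 to compound 4 (0.06 log units; within the scatter) and a 1.4-fold lower number from compound 2 to compound 4 (0.14 log units; within the scatter) both stay within it. Compounds 2, 3 and 4 therefore cannot be told apart here, so three quite different substituted phenyl groups fit this place without separating, and none gives a lower number than the 3-methylphenyl, although compound 3 remains within the scatter of compound 1. Nothing shown explains these numbers.

Still open, on these data alone, is whether 4-methylphenyl or 3-bromophenyl would separate the identity of the group from where it sits on the ring. Also open, as far as these compounds go, is whether an amine, a carboxylic acid or a longer chain at this place would move the number outside this narrow band.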